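The compounds below may be only part of what the source reports. "The series", "measured", "known", "first", "only" and "open" are said of these compounds alone.

Two measured compounds set the scene. Compound 1 `CC1CCCN(C2CCN(S(=O)(=O)c3ccc(OC(F)F)cc3)CC2)C1` and compound 2 `CC1CCN(C2CCN(S(=O)(=O)c3ccc(-c4ccc(Cl)cc4)cc3)CC2)CC1` share the same core and differ in the aryl sulfonamide portion. In a functional assay on DLD-1 cells (Homo sapiens) for antiproliferative activity, read by CellTiter-Glo, with a stated time of 72 h (on this read-out lower numbers stand for stronger inhibition and higher numbers for weaker inhibition), compound 1 gives 105 nM, and in the same assay compound 2 gives 105 nM, so compound 2 stands level with compound 1 at the digits recorded, with no change beyond the scatter. The step from compound 2 to compound 3 `COc1ccc(-c2ccc(S(=O)(=O)N3CCC(N4CCC(C)CC4)CC3)cc2)cc1` is a single exchange on the outer ring: methoxy in place of chloro on an aromatic carbon, or, read one bond further out, 4-chlorophenyl to 4-methoxyphenyl. For the measured compounds named here, no measured pair in this set carries that exchange, so its effect in this assay cannot be read from the data; the expectation is a step no larger than the scatter, in either direction. Compound 3 is therefore expected to give 150 nM, with a range from 50 nM to 500 nM. That estimate means an expected step of a 1.4-fold higher number from compound 2 to compound 3 (0.15 log units; within the scatter).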

Compound 3, half-maximal inhibitory concentration: 263 nM
Compound 3: the middle estimate sits 1.8-fold (0.24 log units) below what was measured; the range from low to high includes it.
By their numbers in this assay, from the lowest: compounds 1 and 2 (each within the scatter of the next); then compound 3.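

In this assay, putting methoxy in place of chloro on an aromatic carbon, para to a large group, gives a 2.5-fold higher number from compound 2 to compound 3 (0.40 log units; beyond the scatter), a modest change but the first in this set to lie beyond the scatter. This shows that the outer ring position is not indifferent to its substituent: with methoxy the number is higher than with chloro, though the change costs only part of the activity. Nothing at hand explains this step.

From the compounds shown here alone, a single exchange gives no trend, so it remains open how a fluoro group, a nitrile, an amine or a carboxylic acid at this position would read in this assay or whether a longer alkoxy chain would raise the number further. Going by these compounds, it is also open whether methoxy would give a step of similar size on a different core.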